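The compounds below may be only part of what the source reports. "The series", "measured", "known", "first", "only" and "open" are said of these compounds alone.

Compound 2 `COc1cccc(CNCCCNc2ccnc3cc(Oc4cccc(N(C)C)c4)ccc23)c1O` is the reference point here. In a physicochemical assay for solubility, with a stated time of 18 h, at pH 7.4 (on this read-out lower numbers stand for lower solubility and higher numbers for higher solubility), compound 2 gives 14500 nM, level with compound 1 `COc1cccc(Oc2ccc3c(NCCCNCc4cccc(OC)c4O)ccnc3c2)c1`, which in this assay gives 14500 nM; the two differ only by no change at the digits printed from compound 1 to compound 2 (within the scatter), a step reported as no change within the scatter.

Compound 3 `COc1ccccc1Oc1ccc2c(NCCCNCc3cccc(OC)c3O)ccnc2c1` has not been measured in this assay. It differs from compound 2 by 2-methoxyphenyl in place of 3-(dimethylamino)phenyl on an oxygen on an aromatic ring. For the measured compounds named here, the one measured step that bears on this, from compound 1 to compound 2, swapped methoxy for dimethylamino on the same aromatic ring and moved the read-out not at all; compound 3 now carries a methoxy again, though as 2-methoxyphenyl rather than the 3-methoxyphenyl of compound 1. Going by the values given here, no measured step addresses that shift of the methoxy position, so the expectation rests on the flat step already seen.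

For compound 3 the expected step in this assay is therefore no change at the digits printed from compound 2 to compound 3 (within the scatter), meaning no change beyond the scatter. Compound 3 is estimated at 14500 nM, with a range of 7000 nM to 29000 nM.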

Compound 3, solubility: 14500 nM
For compound 3 middle estimate and measured number coincide at the digits printed; the range from low to high includes it.
By their numbers in this assay, from the lowest: compounds 1, 2 and 3 (each within the scatter of the next).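

In this assay, 2-methoxyphenyl in place of 3-(dimethylamino)phenyl on the oxygen gives no change at the digits printed from compound 2 to compound 3 (within the scatter) and so adds a second flat step at this position. For the compounds shown here, the step 2-methoxyphenyl in place of 3-methoxyphenyl gives no change at the digits printed from compound 1 to compound 3 (within the scatter) and is the first reading on where the methoxy sits on this ring, which the earlier pair could not supply. Across compound 1, compound 2 and compound 3, this position therefore shows no difference beyond the scatter for these three aryl groups, and no measurement shown here explains that flatness.

On these data alone, all three groups on this oxygen are substituted phenyl rings, so it remains open whether a carboxylic acid on the ring, a piperidine or a longer chain between the oxygen and the ring would leave the read-out flat. As far as these compounds go, the shared core and the side chain stay constant throughout, so changes there also remain open.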